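From an Acetoxymethyl Compound to an Amino Ester

This account rests on a few compounds, and the source may have more. Where it says the series, first, only, none or still open, it means among the compounds named here.

Compound 1 `CC(O)c1cn(Cc2ccc(Cl)cc2)c2ccccc12`: 19900 nM
Compound 2 `CC(=O)OCc1cn(Cc2ccc(Cl)cc2)c2ccccc12`: 63 nM
Compound 3 `COC(=O)CNCc1cn(Cc2ccc(Cl)cc2)c2ccccc12`: not yet measured

Both values come from a functional assay on T29Kt1 cells (Homo sapiens) for cytotoxicity, read by sulforhodamine B assay, with a stated time of 3 days; on this read-out higher numbers stand for weaker inhibition and lower numbers for stronger inhibition. Compound 2 holds the lower of the two numbers at 63 nM. Compound 3 differs from it as follows: ((methoxycarbonyl)methyl)amino in place of acetoxy on a saturated chain carbon bound to an aromatic carbon. Thus ((methoxycarbonyl)methyl)amino stands in place of acetoxy on a saturated chain carbon bound to an aromatic carbon. Going by the values given here, the only measured step that bears on this is a 320-fold lower number from compound 1 to compound 2 (2.50 log units; beyond the scatter), which also altered the group on the aromatic carbon. One step is thin support, but a sizeable move to a higher number is expected. The expected change is a 16-fold higher number from compound 2 to compound 3 (1.20 log units; beyond the scatter). For compound 3 the estimate is 1000 nM, with an expected range of 120 nM to 12000 nM.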

Compound 3, half-maximal inhibitory concentration: 5010 nM
Compound 3: the middle estimate sits 5.0-fold (0.70 log units) below what was measured; low and high end bracket the measured number.
By their numbers in this assay, from the lowest: compound 2; then compound 3; then compound 1.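

In this assay, the position proves sensitive to what is attached through this saturated chain carbon: ((methoxycarbonyl)methyl)amino in place of acetoxy gives an 80-fold higher number from compound 2 to compound 3 (1.90 log units; beyond the scatter), so an ester carbonyl somewhere in the group does not by itself preserve the low number. The amino ester still keeps a smaller edge over the alcohol, with a 4.0-fold lower number from compound 1 to compound 3 (0.60 log units; beyond the scatter). Nothing available explains either step.

Still open, going by these compounds, is whether the nitrogen or the methoxycarbonyl end accounts for the rise. A simple aminomethyl group or the corresponding carboxylic acid would help separate the two.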